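This account rests on a few compounds, and the source may have more. Where it says the series, first, only, none or still open, it means among the compounds named here.

Working notes on the piperidine amide series, step from compound 3 to compound 4.

Compound 3 `O=C(C1CCN(c2ccccc2)CC1)N1N=CCC1c1ccccc1` stands highest of the three numbers in a physicochemical assay for lipophilicity, read by HPLC, measured as chromatographic lipophilicity, at pH 7.4 (on this read-out higher numbers stand for higher lipophilicity and lower numbers for lower lipophilicity), giving 6.3. Compound 1 `O=C(C1CCCCC1)N1CCC(C(=O)N2N=CCC2c2ccccc2)CC1` is nearest, giving 5.4; compound 2 `CN1CCC(C(=O)N2N=CCC2c2ccccc2)CC1` is furthest, giving 1.1. The measured steps are a number 0.90 log units higher from compound 1 to compound 3 (beyond the scatter), a number 4.30 log units lower from compound 1 to compound 2 (beyond the scatter) and a number 5.20 log units higher from compound 2 to compound 3 (beyond the scatter).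

Compound 4 `O=C(c1c[nH]nn1)N1CCC(C(=O)N2N=CCC2c2ccccc2)CC1` differs from compound 3 as follows: (1H-1,2,3-triazol-4-yl)carbonyl in place of phenyl on an amine nitrogen in a ring. Going by the values given here, the step bearing most directly is a number 0.90 log units higher from compound 1 to compound 3 (beyond the scatter), which shows how far a carbonyl-linked ring on that amine nitrogen sits from phenyl; no step between cyclohexylcarbonyl and (1H-1,2,3-triazol-4-yl)carbonyl is available. The entering group brings 1 hydrogen-bond donor and 3 hydrogen-bond acceptors where the leaving phenyl had none, so a large downward step in this assay is expected, beyond the scatter, and larger than the reversal of compound 1 to compound 3 alone.

For compound 4 the expected step is a number 4.00 log units lower from compound 3 to compound 4 (beyond the scatter), with an estimate of 2.3 and a range from 1.3 to 3.3.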

Compound 4, distribution coefficient: 2
For compound 4 the middle estimate is 0.30 log units above the measured one; the measured number falls inside the stated range.
By their numbers in this assay, from the lowest: compound 2; then compound 4; then compound 1; then compound 3.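

In this assay, going by these compounds alone, the carbonyl on the amine nitrogen in the ring does not set the number by itself: a number 3.40 log units lower from compound 1 to compound 4 (beyond the scatter) follows from 1H-1,2,3-triazol-4-yl in place of cyclohexyl on that same carbonyl carbon, a comparison the earlier compounds could not offer. Set against phenyl, the change gives a number 4.30 log units lower from compound 3 to compound 4 (beyond the scatter) and, set against methyl, it gives a number 0.90 log units higher from compound 2 to compound 4 (beyond the scatter) in the same read-out, placing (1H-1,2,3-triazol-4-yl)carbonyl nearer the methyl end of the span at this position. Nothing available bears on what lies behind these steps.

The compounds shown leave open where benzoyl would fall, which would set an all-carbon aromatic ring on the same carbonyl. Also open, going by these compounds, is how a methyl on a triazole ring nitrogen, replacing the ring hydrogen, would read.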